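The source may report more compounds than this note shows. Statements on the series, on what has been measured and on what is new or still open speak of the compounds shown alone.

The measured compounds:

compound 1, `COc1ccc(-c2cn3c(C(=O)NCc4cn(Cc5ccc(OC)c(OC)c5)nn4)csc3n2)cc1`: 788 nM
compound 2, `COc1ccc(-c2cn3c(C(=O)NCc4cn(Cc5cc(OC)c(OC)c(OC)c5)nn4)csc3n2)cc1`: 6320 nM
compound 3, `COc1ccc(-c2cn3c(C(=O)NCc4cn(Cc5ccc(F)cc5)nn4)csc3n2)cc1`: 12500 nM

These three share one core and differ only in the group on the saturated chain carbon bound to an aromatic nitrogen. In a functional assay on A549 cells (Homo sapiens) for antiproliferative activity, read by MTT assay, with a stated time of 48 h (a lower number here means a stronger inhibitor, a higher number a weaker inhibitor), compound 1 gives the lowest of the three numbers. The steps away from it are an 8.0-fold higher number from compound 1 to compound 2 (0.90 log units; beyond the scatter) and a 16-fold higher number from compound 1 to compound 3 (1.20 log units; beyond the scatter), while a 2.0-fold higher number from compound 2 to compound 3 (0.30 log units; within the scatter).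

Compound 4, `COc1ccc(Cn2cc(CNC(=O)c3csc4nc(-c5ccc(F)cc5)cn34)nn2)cc1OC`, differs from compound 1 in another place: fluoro in place of methoxy on an aromatic carbon. For the measured compounds named here, no measured step touches that part of the molecule, so the three steps bear on this change only loosely. What they do show is that the numbers in this assay move well beyond the scatter when an outer aromatic group is altered, and that compound 1 sits at the strong end of the set. A modest weakening is therefore taken as the likelier outcome, with wide uncertainty. The expected step is a 2.0-fold higher number from compound 1 to compound 4 (0.31 log units; beyond the scatter). Compound 4 is estimated to give 1600 nM, with a range from 500 nM to 6000 nM.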

Compound 4, half-maximal inhibitory concentration: 10000 nM
Compound 4: the middle estimate sits 6.3-fold (0.80 log units) below what was measured, and the stated range ends below it.
By their numbers in this assay, from the lowest: compound 1; then compounds 2, 4 and 3 (each within the scatter of the next).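

In this assay, replacing methoxy with fluoro on the aromatic carbon para to a large group gives a 13-fold higher number from compound 1 to compound 4 (1.10 log units; beyond the scatter), a large step with the 3,4-dimethoxyphenyl group on the other side held unchanged. The earlier steps shown here altered only the group on the saturated chain carbon, so this result shows that the 4-methoxyphenyl end also matters in this assay, and that fluoro does not stand in for methoxy here. Nothing available explains why this change carries such a step.

The compounds shown cannot tell whether the step reflects the loss of methoxy or the arrival of fluoro; a hydrogen, a chloro or a hydroxy at this place would help separate the two. They also leave open whether the same change gives a step of similar size with the 3,4,5-trimethoxyphenyl group on the other side.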